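An Acetyl Group Tested on a Second Core

The source may hold more compounds than are shown below. What is called first, only, known or untested is meant among the compounds shown, and "the series" means these compounds.

Of the compounds shown here, three have been measured in a functional assay on MOLT-4 cells (Homo sapiens) for inhibition; a lower number here means a stronger inhibitor, a higher number a weaker inhibitor. Compound 1, `CC(=O)OC(C)n1cnc2c(Cl)nc(I)nc21`, carries an acetyl on the oxygen of its side chain, and in this assay compound 1 gives 12300 nM. Compound 2, `CC(O)n1cnc2c(Cl)nc(I)nc21`, has a free hydroxy at that position instead. In this assay compound 2 reaches only a limit, > 500000 nM, and not a number. The change from compound 2 to compound 1 is acetyl in place of hydrogen on an oxygen on a saturated carbon, and it brings an at least 40-fold lower number from compound 2 to compound 1 (1.60 log units; beyond the scatter). Compound 3, `CC(O)n1cnc2c(N)nc(I)nc21`, differs from compound 2 in its core: the change is amino in place of chloro on an aromatic carbon. In this assay compound 3 also gives only a limit, > 500000 nM. Because of the limit of > 500000 nM in this assay, at which 2 of the 3 values shown sit, the step that the two limits leave unreadable from compound 2 to compound 3 cannot be read.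

Compound 4, `CC(=O)OC(C)n1cnc2c(N)nc(I)nc21`, has not yet been measured. It differs from compound 3 by acetyl in place of hydrogen on an oxygen on a saturated carbon, and the place of this change is the same, word for word, as in the change from compound 2 to compound 1, so it is the same change made on the core of compound 3. Since compound 3 sits at a limit, the starting point for compound 4 is not known exactly; the expected step is an at least 8.3-fold lower number from compound 3 to compound 4 (0.92 log units; beyond the scatter), resting on the step of an at least 40-fold lower number from compound 2 to compound 1 (1.60 log units; beyond the scatter). Compound 4 is therefore estimated to give about 60000 nM in this assay, expected to fall between 10000 nM and 500000 nM.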

Compound 4, half-maximal inhibitory concentration: 436000 nM
For compound 4 the middle estimate is 7.3-fold (0.86 log units) below the measured one; the measured number falls inside the stated range.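

In this assay, the acetyl group on the core of compound 3 gives an at least 1.1-fold lower number from compound 3 to compound 4 (0.05 log units; that floor lies within the scatter); only this floor can be read, so the change there may be very small or as large as on the core of compound 1. The data therefore show neither that the change carries over at full size nor that it carries over differently: the same change on two cores in this assay, an at least 40-fold lower number (1.60 log units; beyond the scatter) from compound 2 to compound 1 and an at least 1.1-fold lower number (0.05 log units; that floor lies within the scatter) from compound 3 to compound 4; the limit leaves it open whether they differ The two acetyl compounds, which differ only in amino versus chloro, do have true numbers, and they give a 35-fold higher number from compound 1 to compound 4 (1.55 log units; beyond the scatter), so with the acetyl group in place the two cores still stand well apart.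

Going by these compounds, the true values of the two hydroxy compounds remain open, and the step between them cannot be read, because both sit at the same limit: the limit of > 500000 nM in this assay, at which 2 of the 4 values shown sit. It also remains open whether a longer acyl chain such as propionyl, in place of the acetyl, would follow the same course on both cores, or whether a methylamino group in place of the amino would alter the gap between them.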